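From fluoro to tert-butoxy on the aromatic ring

The compounds below may be only part of what the source reports. "The series", "measured", "known", "first", "only" and "open" are said of these compounds alone.

Compound 1 (`O=[N+]([O-])c1ccc(-c2nnc(SCCCN3CCN(c4nc5ccccc5s4)CC3)o2)cc1`) and compound 2 (`Fc1ccc(-c2nnc(SCCCN3CCN(c4nc5ccccc5s4)CC3)o2)cc1`) share one core and differ only in a single group on an aromatic carbon. In a functional assay on MCF7 cells (Homo sapiens) for inhibition, read by MTT assay, with a stated time of 72 h (on this read-out lower numbers stand for stronger inhibition and higher numbers for weaker inhibition), compound 1 gives 118000 nM and compound 2 gives 84100 nM. These two numbers lie within the scatter of each other, so compound 2 cannot be told apart from compound 1 on this read-out.

Compound 3 (`CC(C)(C)Oc1ccc(-c2nnc(SCCCN3CCN(c4nc5ccccc5s4)CC3)o2)cc1`) keeps the core of compound 2 but carries tert-butoxy in place of fluoro on an aromatic carbon, para to a large group: tert-butoxy in place of fluoro on an aromatic carbon.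

Among the compounds with values here, only one measured step bears on this change. It is a 1.4-fold lower number from compound 1 to compound 2 (0.15 log units; within the scatter), with fluoro in place of nitro at the same place, and it offers no ground for expecting a large move in this assay. Within the data shown here, no measured compound carries tert-butoxy, so the expectation remains loose and the range is kept wide. The expected step is a 1.1-fold lower number from compound 2 to compound 3 (0.02 log units; within the scatter), which would stay within the scatter. For compound 3 the estimated value is 80000 nM, with an expected range from 35000 nM to 160000 nM.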

Compound 3, half-maximal inhibitory concentration: 89300 nM
Compound 3: middle estimate off by 1.1-fold (0.05 log units), on the low side, within the range that was stated.
By their numbers in this assay, from the lowest: compounds 2, 3 and 1 (each within the scatter of the next).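

In this assay, putting tert-butoxy in place of fluoro gives a 1.1-fold higher number from compound 2 to compound 3 (0.03 log units; within the scatter), and putting it in place of nitro gives a 1.3-fold lower number from compound 1 to compound 3 (0.12 log units; within the scatter), so nitro, fluoro and tert-butoxy cannot be told apart at this place on the read-out. Within the data shown here, the earlier pair showed this for only two groups, each small; the new step shows that a group of five heavy atoms, bringing one hydrogen-bond acceptor in place of a single fluorine, also stays within the scatter on this aromatic carbon, para to a large group. No further data on these compounds bear on the reason for this result.

The compounds shown leave open whether an amine or a carboxylic acid on this aromatic carbon would separate from these three, as all three groups so far give numbers that cannot be told apart. They also leave open whether a change elsewhere on the shared core would move the number beyond the scatter, as every step shown lies at this one place.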